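Removing the methyl from the quinoline ether of compound 2

A few compounds are considered here, and "the series" means these few. Any claim that something is new, unique, unknown or untested is made for them only; others in the source may bear on it.

Compound 1, `C=C1CC[C@@H]2[C@](C)(COC(C)=O)[C@H](O)CC[C@@]2(C)[C@@H]1C/C=C1/C(=O)OC[C@@H]1Oc1cccc2cccnc12`, has been measured in an ADME assay on SNB-19 cells (Homo sapiens) for cytotoxicity, read by MTT assay, with a stated time of 24 h (a lower number here means that less compound is tolerated, a higher number that more compound is tolerated), where compound 1 gives 49500 nM. Compound 2, `C=C1CC[C@@H]2[C@](C)(CO)[C@H](O)CC[C@@]2(C)[C@@H]1C/C=C1/C(=O)OC[C@@H]1Oc1cccc2ccc(C)nc12`, carries a free hydroxymethyl in place of the acetate and a methyl on the quinoline; in this assay compound 2 reaches only a limit, > 100000 nM. That value is a limit of the measurement and not a number: the limit of > 100000 nM in this assay, at which 1 of the 2 values shown sits. Among the compounds with values here, compounds 1 and 2 differ in two places, so no single step between them is known, and their two values show only that compound 1 sits at a number while compound 2 sits at the limit.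

Compound 3, `C=C1CC[C@@H]2[C@](C)(CO)[C@H](O)CC[C@@]2(C)[C@@H]1C/C=C1/C(=O)OC[C@@H]1Oc1cccc2cccnc12`, has not yet been measured in this assay. It differs from compound 2 by hydrogen in place of methyl on an aromatic carbon. With compound 2 standing at the limit, the starting point of this step is itself uncertain. The step from compound 2 to compound 3 is expected to be an at least 1.1-fold lower number from compound 2 to compound 3 (0.04 log units; that floor lies within the scatter), which is nothing beyond the scatter. Compound 3 is therefore expected to show 90000 nM, in a range from 40000 nM to 200000 nM, with a fair chance that this assay again reports only a limit.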

Compound 3, half-maximal cytotoxic concentration: 22700 nM
For compound 3 the middle estimate is 4.0-fold (0.60 log units) above the measured one, and the stated range ends above it.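

In this assay, with the free hydroxymethyl held constant, the change from 2-methylquinolin-8-yl to quinolin-8-yl gives an at least 4.4-fold lower number from compound 2 to compound 3 (0.64 log units; beyond the scatter), so the methyl on this aromatic carbon next to the ring nitrogen matters for how much compound the cells tolerate, and removing it leaves less tolerated. With the quinolin-8-yl group held constant, hydrogen in place of acetyl on the oxygen gives a 2.2-fold lower number from compound 1 to compound 3 (0.34 log units; beyond the scatter), a separate and modest contribution from the second place. Compound 1 and compound 2 differ in both places. On their own they could not separate this contribution from the first. The first of these two steps has only a lower bound on its size, and its true size remains unknown, since the value of compound 2 is a limit and not a number: the limit of > 100000 nM in this assay, at which 1 of the 3 values shown sits.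

The compounds shown leave open whether the methyl step keeps its size when acetyl sits on the oxygen, since both steps were read with the free hydroxymethyl in compound 3. They also leave open how an ethyl group, a chlorine or an amine on the same aromatic carbon would compare with methyl and hydrogen.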